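A Fluoro Substituent Added to Compound 2

This account rests on a few compounds, and the source may have more. Where it says the series, first, only, none or still open, it means among the compounds named here.

Compound 1, `Nc1ccccc1NC(=O)c1ccc(CSC(=S)N2CCN(Cc3ccccn3)CC2)cc1`, gives 61.4%
Compound 2, `Nc1ccccc1NC(=O)c1ccc(CSC(=S)N2CCN(c3ccccc3)CC2)cc1`, gives 73.1%
Compound 3, `Nc1ccccc1NC(=O)c1ccc(CSC(=S)N2CCCc3ccccc32)cc1`, gives 35.7%

These three compounds share one core and were measured in a functional assay on HeLa cells (Homo sapiens) for antiproliferative activity, read by CCK-8 assay, with a stated time of 72 h, tested at 8 uM; a lower number here means a weaker effect, a higher number a stronger effect of the compound at the concentration tested. Compound 2 stands highest of the three numbers: compound 1 comes nearest, and compound 3 lies furthest away, with both gaps beyond the scatter. Among the compounds with values here, the one step between compounds that differ in a single place is a number 11.7 percentage points higher from compound 1 to compound 2 (beyond the scatter), a modest rise brought by phenyl in place of (pyridin-2-yl)methyl on an amine nitrogen in a ring.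

The next compound, compound 4, `Nc1ccccc1NC(=O)c1ccc(CSC(=S)N2CCN(c3ccc(F)cc3)CC2)cc1`, differs from compound 2 in one place: fluoro in place of hydrogen on an aromatic carbon. Within the data shown here, no measured step in this set concerns fluoro on an aromatic carbon, so the step from compound 1 to compound 2 bears on it only indirectly, by showing that the group on the amine nitrogen in the ring matters to the read-out. Among the measured compounds shown here, with no direct precedent, the expectation is a step of a number 1.1 percentage points lower from compound 2 to compound 4 (within the scatter) in this assay, that is, none beyond the scatter. Compound 4 is therefore estimated at 72%, within a range from 58% to 84%.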

Compound 4, a percentage reported as inhibition, at one concentration (the size of the read-out at that concentration, not a potency): 64.5%
Beside the measured number, compound 4's estimate is 7.5 percentage points above it, and the stated range covers the measured number.
By their numbers in this assay, from the lowest: compound 3; then compounds 1, 4 and 2 (each within the scatter of the next, the first and the last beyond it).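

Fluoro in place of hydrogen on the aromatic carbon para to a large group, the first change tested on this ring of compound 2, comes with a number 8.6 percentage points lower from compound 2 to compound 4 (within the scatter) in this assay and so shows no change that can be told from the scatter. The comparison with the pyridinylmethyl compound shifts as well: a number 11.7 percentage points higher from compound 1 to compound 2 (beyond the scatter) lay beyond the scatter, but a number 3.1 percentage points higher from compound 1 to compound 4 (within the scatter) does not, so compound 4 sits within the scatter of two compounds that differ clearly from each other. The single fluorine therefore cannot be assigned to either side of that gap, and no measurement shown here offers an explanation for where compound 4 falls.

On these data alone, one substituent at one place on the phenyl ring says little about the position as a whole, so it remains open whether a chloro, a methoxy, an amine or a trifluoromethyl group there would move the read-out beyond the scatter. Each number is also a percentage at a single concentration, so whether compound 2 and compound 4 differ in potency stays unresolved.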